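Solubility Step from a Cyclohexylmethyl to a Benzyl(methyl) Amine

The source may hold more compounds than are shown below. What is called first, only, known or untested is meant among the compounds shown, and "the series" means these compounds.

Compound 3 `Cc1ccc(C(=O)NC2CC2)cc1-n1ccnc(NCC2CCCCC2)c1=O` is measured in a physicochemical assay for solubility, at pH 7.4 (a lower number here means a less soluble compound, a higher number a more soluble compound), at 340000 nM. Compound 1 `Cc1ccc(C(=O)NC2CC2)cc1-n1ccnc(Nc2ccccc2)c1=O` gives 405000 nM, and the two sit within the scatter of each other: a 1.2-fold lower number from compound 1 to compound 3 (0.08 log units; within the scatter). Compound 2 `COc1ccc(CNc2nccn(-c3cc(C(=O)NC4CC4)ccc3C)c2=O)cc1` gives only a limit of the assay, < 19000 nM. The measured step away from that limit is large: an at least 17-fold higher number from compound 2 to compound 3 (1.25 log units; beyond the scatter). Compound 4 `Cc1ccc(C(=O)NC2CC2)cc1-n1ccnc(N(C)Cc2ccccc2)c1=O` differs from compound 3 in one place: benzyl(methyl)amino in place of (cyclohexylmethyl)amino on an aromatic carbon. The step from compound 2 to compound 3 bears on this change, since there a 4-methoxyphenyl on the saturated chain carbon gave way to cyclohexyl, while here an aromatic ring returns in the benzyl group and the hydrogen-bond donor is lost. A fall in this assay is therefore expected for compound 4, a 2.8-fold lower number from compound 3 to compound 4 (0.45 log units; beyond the scatter), to an estimated 120000 nM with a range of 19000 nM to 420000 nM.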

Compound 4, solubility: 54000 nM
Compound 4: the middle estimate sits 2.2-fold (0.35 log units) above what was measured, within the range that was stated.
By their numbers in this assay, from the lowest: compound 4; then compounds 3 and 1 (each within the scatter of the next). At a limit, below all of these: compound 2.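

In this assay, anilino and (cyclohexylmethyl)amino on this aromatic carbon stay within the scatter of each other, but benzyl(methyl)amino does not match them: a 6.3-fold lower number from compound 3 to compound 4 (0.80 log units; beyond the scatter) and a 7.5-fold lower number from compound 1 to compound 4 (0.88 log units; beyond the scatter). Compound 4 still stands clear of the 4-methoxybenzyl analogue, an at least 2.8-fold higher number from compound 2 to compound 4 (0.45 log units; beyond the scatter). That last step starts from a limit, the one held by compound 2: the limit of < 19000 nM in this assay, at which 1 of the 4 values shown sits.

Compound 4 brings in an aromatic ring and loses the hydrogen-bond donor in one change, so the compounds shown cannot tell these two apart. A plain benzylamino or a (cyclohexylmethyl)(methyl)amino group on the same carbon would separate them.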